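Methyl for Chloro on the Aniline Ring: Compound 3 Predicted

The source may hold more compounds than are shown below. What is called first, only, known or untested is meant among the compounds shown, and "the series" means these compounds.

Measured so far:
Compound 1 `Cc1nc(Nc2cccc(Cl)c2)sc1C(=O)/C=C/c1ccc(Cl)cc1`: > 25000 nM
Compound 2 `COc1cc(/C=C/C(=O)c2sc(Nc3cccc(Cl)c3)nc2C)cc(OC)c1OC`: > 25000 nM

Both values come from a functional assay on PC-3 cells (Homo sapiens) for cytotoxicity, read by MTT assay (on this read-out lower numbers stand for stronger inhibition and higher numbers for weaker inhibition), and both are limits of the assay, not numbers. Compound 2 gives > 25000 nM in this assay, which is a limit. Compound 1 likewise gives a limit, > 25000 nM. So compound 2 stands at the limit of > 25000 nM in this assay, at which 2 of the 2 values shown sit, with nothing measured beyond it.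

Compound 3 `COc1cc(/C=C/C(=O)c2sc(Nc3cccc(C)c3)nc2C)cc(OC)c1OC` has not yet been measured. It differs from compound 2 by methyl in place of chloro on an aromatic carbon, on the ring that hangs from the amino group. Among the measured compounds shown here, no measured pair in this set shows what such a swap does, so no size of step can be drawn from the data.

Given that compound 2 shows only a limit in this assay, compound 3 is expected to be little different, with the step that the limit leaves unreadable from compound 2 to compound 3 staying within the usual scatter. The estimate for compound 3 is 35000 nM, most likely again reported as a limit, with a range from 10000 nM to 120000 nM.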

Compound 3, half-maximal inhibitory concentration: > 25000 nM
Compound 3: only a limit was reported (the forecaster's own chance of this, stated with the estimate: 75%); the middle value does not contradict the limit.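

Compound 2 and compound 3 both sit at a limit in this assay, so no step between them can be read: the limit of > 25000 nM in this assay, at which 3 of the 3 values shown sit.

On these data alone, what methyl in place of chloro does here stays open, as does which change to the shared core, if any, would give a readable number in this assay.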